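Shifting a hydroxyl on a triaryl pyridine scaffold

This account rests on a few compounds, and the source may have more. Where it says the series, first, only, none or still open, it means among the compounds named here.

Measured so far in a functional assay on DU-145 cells (Homo sapiens) for cytotoxicity, read by CCK-8 assay, with a stated time of 4 days; a lower number here means a stronger inhibitor, a higher number a weaker inhibitor:
- compound 1, `Oc1cccc(-c2cc(-c3ccccc3O)nc(-c3ccccc3O)c2)c1`, gives 5400 nM
- compound 2, `Oc1ccc(-c2cc(-c3ccccc3O)cc(-c3ccccc3O)n2)cc1`, gives 360 nM

Compound 2 stands as the lower of the two numbers, and compound 1 lies well beyond the scatter above it. Compound 3, `Oc1ccc(-c2cc(-c3cccc(O)c3)cc(-c3ccccc3O)n2)cc1`, differs from compound 2 by 3-hydroxyphenyl in place of 2-hydroxyphenyl on an aromatic carbon. Among the compounds with values here, no measured pair shows this exact change, so its size is uncertain. Compound 1, which also carries a 3-hydroxyphenyl, is the weaker measured compound, so a modest loss is expected, as a 2.2-fold higher number from compound 2 to compound 3 (0.35 log units; beyond the scatter) in this assay. Compound 3 is therefore estimated at 800 nM, with a range from 250 nM to 2500 nM.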

Compound 3, half-maximal inhibitory concentration: > 50000 nM
Compound 3 was reported as a limit; the forecaster's own chance of this, stated with the estimate: 3%; middle value at least 62-fold (1.79 log units) away from the limit.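

Moving a single hydroxyl is no small edit at this position, opposite the ring nitrogen: 3-hydroxyphenyl in place of 2-hydroxyphenyl gives an at least 130-fold higher number from compound 2 to compound 3 (2.14 log units; beyond the scatter) in this assay. A different single swap, 4-hydroxyphenyl in place of 2-hydroxyphenyl, gives an at least 9.2-fold higher number from compound 1 to compound 3 (0.96 log units; beyond the scatter) in this assay, so both changes lead to a weaker compound. Compound 3 is reported as a limit and not as a number: the limit of > 50000 nM in this assay, at which 1 of the 3 values shown sits.

On these data alone, the true size of both losses stays open. So does whether a methoxy group or an amine in place of the hydroxyl of the 2-hydroxyphenyl group would keep the strength of compound 2.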